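A few compounds are considered here, and "the series" means these few. Any claim that something is new, unique, unknown or untested is made for them only; others in the source may bear on it.

Measured so far:
- Compound 1 `CN(Cc1ccc(C(F)(F)F)cc1)c1cc(C(=O)Nc2ccccc2)ncn1`: < 5000 nM (a limit)
- Compound 2 `CN(Cc1ccc(C(F)(F)F)cc1)c1cc(C(=O)NC2CCCCC2)ncn1`: 5000 nM

For the measured compounds named here, in a physicochemical assay for solubility, using the shake flask method, measured as kinetic solubility, with a stated time of 2 h, at pH 7.4 (on this read-out lower numbers stand for lower solubility and higher numbers for higher solubility), compound 2 gives 5000 nM, the only actual number available so far. Compound 1 gives < 5000 nM, which is a limit of the assay and not a number.

The next compound, compound 3 `CN(Cc1ccc(C(F)(F)F)cc1)c1cc(C(=O)Nc2ncn(C)n2)ncn1`, keeps the rest of compound 2 but carries 1-methyl-1H-1,2,4-triazol-3-yl in place of cyclohexyl on an amide-type nitrogen.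

Going by the values given here, only one measured step bears on this change, since it concerns the same nitrogen: a number no lower from compound 1 to compound 2 (the limit leaves the size open). There, cyclohexyl replaced phenyl, but the size of the step cannot be read, so it offers no size to carry over. That leaves only the structural change itself as a guide, and a reading of this assay reported only as a limit remains possible. The expected step is a 2.0-fold higher number from compound 2 to compound 3 (0.30 log units; within the scatter), a modest rise held with wide uncertainty. For compound 3 the estimated value is 10000 nM, with an expected range of 4000 nM to 40000 nM.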

Compound 3, solubility: 173000 nM
Estimate against measurement, compound 3: 17-fold (1.24 log units) below, outside the stated range (above it).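

In this assay, the group on the amide-type nitrogen now proves able to shift the read-out by a large amount, which the earlier pair could not show because its step had no readable size: 1-methyl-1H-1,2,4-triazol-3-yl in place of cyclohexyl gives a 35-fold higher number from compound 2 to compound 3 (1.54 log units; beyond the scatter). The two groups have the same number of heavy atoms, so this step does not come with a difference in that count; what differs is the type of ring and the atoms in it, with nitrogen and hydrogen-bond acceptors present only in the entering group. The same group in place of phenyl gives an at least 34-fold higher number from compound 1 to compound 3 (1.53 log units; beyond the scatter), and this step starts from a limit and not from a number: the limit of < 5000 nM in this assay, at which 1 of the 3 values shown sits.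

The compounds shown cannot tell whether the large step follows the ring nitrogens, the five-membered aromatic ring or its methyl group. A 1-methylpyrazol-3-yl group, a pyridine ring or the same triazole without its methyl group on this nitrogen would begin to separate these features.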